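This account rests on a few compounds, and the source may have more. Where it says the series, first, only, none or still open, it means among the compounds named here.

Compound 1 `NC1CCC(Nc2nc(NCc3ccc(Br)cc3)c3ncn(C4CCCC4)c3n2)CC1`: 850 nM
Compound 2 `CC(C)(O)CNc1nc(NCc2ccc(-c3ccco3)nc2)c2ncn(C3CCCC3)c2n1`: 1310 nM

Both numbers come from a functional assay on MCF7 cells (Homo sapiens) for inhibition, with a stated time of 72 h; on this read-out lower numbers stand for stronger inhibition and higher numbers for weaker inhibition. Compound 1 stands at one end of this pair, yet the gap to compound 2 lies within the usual scatter of this assay, so the two cannot be told apart on these figures; compound 1 is simply the starting point for the step that follows.

Compound 3 `NC1CCC(Nc2nc(NCc3cc(Cl)ccc3O)c3ncn(C4CCCC4)c3n2)CC1` has not yet been measured in this assay. It differs from compound 1 in one place: 5-chloro-2-hydroxyphenyl in place of 4-bromophenyl on a saturated chain carbon bound to a nitrogen on an aromatic ring. Going by the values given here, no pair of measured compounds shows what such a change does here, so there is no measured step to lean on. Since the change is confined to one group and the shared core is kept, only a modest step is expected, one that may well stay within the scatter, with a slight lean toward a higher number. On that basis compound 3 is estimated at 1200 nM, within 300 nM to 5000 nM, which means an expected step of a 1.4-fold higher number from compound 1 to compound 3 (0.15 log units; within the scatter).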

Compound 3, half-maximal inhibitory concentration: 430 nM
For compound 3 the middle estimate is 2.8-fold (0.45 log units) above the measured one; the range from low to high includes it.
By their numbers in this assay, from the lowest: compounds 3, 1 and 2 (each within the scatter of the next, the first and the last beyond it).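

In this assay, placing 5-chloro-2-hydroxyphenyl in place of 4-bromophenyl on a saturated chain carbon bound to a nitrogen on an aromatic ring gives a 2.0-fold lower number from compound 1 to compound 3 (0.30 log units; within the scatter), so compound 1 and compound 3 cannot be told apart on these figures. This position therefore accepts a quite different ring, carrying chlorine and a hydroxyl with its hydrogen-bond donor instead of bromine, without the number moving beyond the usual scatter. No independent measurement is available here to explain this result.

On these data alone, the swap alters the halogen and adds the hydroxyl in a single step, so the separate share of each remains unknown. A plain phenyl ring, or a methoxy group in place of the hydroxyl, would be needed to begin separating the two.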